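The source may hold more compounds than are shown below. What is called first, only, known or untested is meant among the compounds shown, and "the series" means these compounds.

Compound 3 `COc1cccc(-c2ccc([C@H]3S[C@@H](C)C(=O)Nc4c3c(C)nn4-c3ccccc3C)cc2)c1` is an analogue of compound 1 `Cc1ccccc1-n1nc(C)c2c1NC(=O)[C@H](C)S[C@@H]2c1ccc(-c2ccoc2)cc1` that carries 3-methoxyphenyl where compound 1 carries furan-3-yl. In an assay on isolated protein for agonist activity at Bile acid receptor (Homo sapiens), read by AlphaScreen, with a stated time of 30 min (a lower number here means a smaller maximal response, a higher number a larger maximal response), compound 3 gives 41%, the second highest of the three measured values; compound 1 gives 40%, and compound 2 `COc1ccc(C2SC(C)C(=O)Nc3c2c(C)nn3-c2ccccc2C)c(OC)c1` gives 63%, clearly above compound 3. Among the compounds with values here, the one measured step that bears on the question, a number 1 percentage points higher from compound 1 to compound 3 (within the scatter), stayed within the scatter. Compound 4 `Cc1ccccc1-n1nc(C)c2c1NC(=O)[C@H](C)S[C@@H]2c1ccc(-c2ccsc2)cc1` differs from compound 3 by thiophen-3-yl in place of 3-methoxyphenyl on an aromatic carbon. Because compound 1 with its five-membered furan-3-yl gave 40%, the return to a five-membered ring in compound 4 is expected to leave the maximal response about where it is, with an expected a number 1 percentage points lower from compound 3 to compound 4 (within the scatter). Compound 4 is therefore estimated at 40%, within a range from 30% to 52%.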

Compound 4, largest response reached (reported as efficacy), in percent of the reference or control that the assay uses: 68%
Beside the measured number, compound 4's estimate is 28 percentage points below it; measured number above the stated range.
By their numbers in this assay, from the lowest: compounds 1 and 3 (each within the scatter of the next); then compounds 2 and 4 (each within the scatter of the next).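

In this assay, the group on this aromatic carbon, para to a large group, proves able to move the maximal response: thiophen-3-yl in place of 3-methoxyphenyl gives a number 27 percentage points higher from compound 3 to compound 4 (beyond the scatter) and thiophen-3-yl in place of furan-3-yl gives a number 28 percentage points higher from compound 1 to compound 4 (beyond the scatter). Ring size alone therefore does not settle the outcome, as furan-3-yl and thiophen-3-yl are both five-membered rings. No available evidence accounts for the difference. Going by these compounds, whether other five-membered rings would follow thiophen-3-yl or furan-3-yl remains open, as does the response with an amine or a carboxylic acid on this carbon.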